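Furan Replaced by Substituted Pyridine on a Thiazole Acetic Acid

This account rests on a few compounds, and the source may have more. Where it says the series, first, only, none or still open, it means among the compounds named here.

Measured compounds:
compound 1, `O=C(O)Cc1sc(C(c2ccccc2)c2ccc(F)cc2)nc1-c1ccc(Cl)cc1`, 36 nM
compound 2, `O=C(O)Cc1sc(C(c2ccc(F)cc2)c2ccc(F)cc2)nc1-c1ccco1`, 140 nM

Of the compounds shown here, two have been tested in an in vitro functional assay on HEK285-7 cells for antagonist activity at prostaglandin D2 receptor 2 (Homo sapiens), read by BRET and beta-arrestin recruitment; on this read-out lower numbers stand for stronger inhibition and higher numbers for weaker inhibition. Compound 1 gives 36 nM, and compound 2 gives 140 nM. Compound 2 therefore stands with the higher of the two numbers, and the gap to compound 1 lies beyond the usual scatter of this assay. Among the compounds with values here, the two compounds differ in more than one place, so their values show only that a chlorophenyl-bearing analogue reached the lower number.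

Compound 3, `O=C(O)Cc1sc(C(c2ccc(F)cc2)c2ccc(F)cc2)nc1-c1ccnc(N2CCC2)c1`, has not yet been measured. It differs from compound 2 in one place: 2-(azetidin-1-yl)pyridin-4-yl in place of furan-2-yl on an aromatic carbon. The group that enters is larger and carries an additional hydrogen-bond acceptor. Within the data shown here, with no single-point step between measured compounds to lean on, the expectation rests on compound 2 alone. In this assay compound 3 is expected to give 50 nM, within a range from 15 nM to 160 nM. This estimate means a step of a 2.8-fold lower number from compound 2 to compound 3 (0.45 log units; beyond the scatter), a moderate move toward a lower number that is expected to reach beyond the scatter.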

Compound 3, half-maximal inhibitory concentration: > 100000 nM
Compound 3: no number, only a limit; the forecaster's own chance of this, stated with the estimate: 2%; at least 2000-fold (3.30 log units) between middle value and limit.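

In this assay, compound 3 has no number, only a limit of the assay: the limit of > 100000 nM in this assay, at which 1 of the 3 values shown sits. Putting 2-(azetidin-1-yl)pyridin-4-yl in place of furan-2-yl on this aromatic carbon, next to the ring nitrogen, gives an at least 710-fold higher number from compound 2 to compound 3 (2.85 log units; beyond the scatter), which shows that activity at this position does not survive every aromatic replacement, something compound 1 and compound 2 could not show, as they differ in more than one place. The change brings in the pyridine ring and the azetidine together, so the result does not tell which of the two accounts for it.

As far as these compounds go, it remains open whether a plain pyridin-4-yl group would retain a measurable number. The same is true of a pyridine carrying a methoxy group or an open-chain amine in place of the azetidine.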